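The source may report more compounds than this note shows. Statements on the series, on what has been measured and on what is new or still open speak of the compounds shown alone.

Values in a functional assay on MT2 cells (Homo sapiens) for cytotoxicity, read by MTT assay; on this read-out higher numbers stand for lower toxicity in this test and lower numbers for higher toxicity in this test:
- compound 1 `CCCc1ccc(Nc2nccs2)cc1OCC=C(C)C`: 23000 nM
- compound 2 `Clc1ccc(Nc2nccs2)cc1OCc1cccs1`: 38000 nM
- compound 3 `N#Cc1ccc(Nc2nccs2)cc1OCc1cccs1`: 4100 nM

Compound 2 and compound 1 lie within the scatter of each other, and compound 3 stands apart with the lowest number. Compound 4 `Clc1ccc(Nc2nccs2)cc1OCC1CCCCC1` follows from compound 2 by cyclohexyl in place of thiophen-2-yl on a saturated chain carbon bound to an oxygen on an aromatic ring, that is, (thiophen-2-yl)methyl to cyclohexylmethyl. Among the compounds with values here, the one measured step, a 9.3-fold lower number from compound 2 to compound 3 (0.97 log units; beyond the scatter), is cyano in place of chloro, so it concerns another place and gives no direct guide. The nearest indication is compound 1 at 23000 nM, which carries no thiophen-2-yl yet stays within the scatter of compound 2. No step beyond the scatter is therefore expected in this assay, and the estimated step is a 1.5-fold lower number from compound 2 to compound 4 (0.18 log units; within the scatter). For compound 4 the estimate is 25000 nM, with an expected range of 10000 nM to 60000 nM.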

Compound 4, half-maximal cytotoxic concentration: 15000 nM
Estimate against measurement, compound 4: 1.7-fold (0.22 log units) above, and the stated range covers the measured number.
By their numbers in this assay, from the lowest: compound 3; then compounds 4, 1 and 2 (each within the scatter of the next, the first and the last beyond it).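

In this assay, cyclohexyl in place of thiophen-2-yl gives a 2.5-fold lower number from compound 2 to compound 4 (0.40 log units; beyond the scatter), the first step read at this place, on a saturated chain carbon bound to an oxygen on an aromatic ring. The read-out therefore responds to the ring carried on this chain as well as to the group exchanged in the step from chloro to cyano. No data given here bear on the cause of this step.

As far as these compounds go, whether the loss of the sulfur or the loss of aromatic character drives the step stays open, since both change together. Also open, from the compounds shown here alone, are how an amine, a carboxylic acid or a longer chain at this place would read, and whether cyclohexylmethyl would give a similar step alongside cyano instead of chloro.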